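Three Limits and a Fourth Compound Still to Test

The source may hold more compounds than are shown below. What is called first, only, known or untested is meant among the compounds shown, and "the series" means these compounds.

Compound 1 `CCCc1nc(C)c2c(-c3ccccc3)nnc(SC)n12`: > 48000 nM, a limit of the assay.
Compound 2 `CCn1ncc2c(C)nc(C(C)C)n2c1=O`: > 48000 nM, a limit of the assay.
Compound 3 `CSc1nnc(-c2ccccc2)c2c(C)nc(C(C)C)n12`: > 48000 nM, a limit of the assay.

All three were run in a functional assay for inhibition, with Homo sapiens as the target (a lower number here means a stronger inhibitor, a higher number a weaker inhibitor), and none gave a number. Compound 1 and compound 3 share one core and differ by propyl in place of isopropyl on an aromatic carbon; the step that the two limits leave unreadable from compound 3 to compound 1 has no readable size because of the limit of > 48000 nM in this assay, at which 3 of the 3 values shown sit. Compound 2 has another core, and the difference between the two cores is not broken down here. Compound 4 `CCCc1nc(C)c2cnn(CC)c(=O)n12`, not yet measured, carries the same change relative to compound 2: propyl in place of isopropyl on an aromatic carbon. Because (the limit of > 48000 nM in this assay, at which 3 of the 3 values shown sit), the step that the limit leaves unreadable from compound 2 to compound 4 is expected to be small. Compound 4 is therefore expected to give about 60000 nM in this assay, most likely once more as a limit, somewhere from 20000 nM to 200000 nM.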

Compound 4, half-maximal inhibitory concentration: > 48000 nM
Compound 4: only a limit was reported; the forecaster's own chance of this, stated with the estimate: 85%; the middle value does not contradict the limit.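

In this assay no size can be read for the step between compound 2 and compound 4, because both values are limits: the limit of > 48000 nM in this assay, at which 4 of the 4 values shown sit.

As far as these compounds go, whether propyl or isopropyl gives the stronger inhibitor stays open, and so does the actual number for compounds 1, 2, 3 and 4.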